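Swapping a hydroxyphenyl urea for a chlorophenyl urea

A few compounds are considered here, and "the series" means these few. Any claim that something is new, unique, unknown or untested is made for them only; others in the source may bear on it.

Measured compounds:
- compound 1 `COc1cc(NC(C)CCCNC(=O)NNC(=O)Nc2cc(C(F)(F)F)cc(C(F)(F)F)c2)c2ncccc2c1`: 20000 nM
- compound 2 `COc1cc(NC(C)CCCNC(=O)Nc2ccc(O)cc2)c2ncccc2c1`: 57000 nM

Both were tested in a functional assay on MIA PaCa-2 cells (Homo sapiens) for inhibition, read by MTT assay, with a stated time of 72 h; on this read-out higher numbers stand for weaker inhibition and lower numbers for stronger inhibition. Of the two numbers, compound 2 carries the higher one, so it is the weaker inhibitor of the pair; the gap to compound 1 is beyond the usual scatter of this assay. For the measured compounds named here, no single-point step between the two measured compounds is available, since they differ in more than one place.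

Compound 3 `COc1cc(NC(C)CCCNC(=O)Nc2cccc(Cl)c2)c2ncccc2c1` has not yet been measured. It differs from compound 2 in one place: 3-chlorophenyl in place of 4-hydroxyphenyl on an amide-type nitrogen. Nothing measured here shows what this change does on its own. Going by the values given here, a modest gain in this assay is expected for compound 3 a 1.9-fold lower number from compound 2 to compound 3 (0.28 log units; within the scatter), because compound 1 gives 20000 nM as the only other measured urea-type compound. The estimate for compound 3 is 30000 nM, within a range of 8000 nM to 90000 nM.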

Compound 3, half-maximal inhibitory concentration: 21000 nM
The estimate for compound 3 lay 1.4-fold (0.15 log units) above the measured number; low and high end bracket the measured number.
By their numbers in this assay, from the lowest: compounds 1 and 3 (each within the scatter of the next); then compound 2.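

In this assay, for the compounds shown here, putting 3-chlorophenyl in place of 4-hydroxyphenyl on the amide-type nitrogen gives a 2.7-fold lower number from compound 2 to compound 3 (0.43 log units; beyond the scatter), the first single-change reading, and it shows that the group at this position affects the result. The change is a modest gain, and it comes with the loss of the hydrogen-bond donor and acceptor counted on the leaving group, since the entering group has neither. Nothing measured here explains why the number falls.

The swap alters both the substituent and its place on the ring, so the compounds shown leave open which of these matters, or whether both do. A plain phenyl on the same nitrogen, or a ring carrying a methyl group or a fluorine, could help to separate these effects.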